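A Methyl on the Amide Nitrogen of Compound 3

The source may report more compounds than this note shows. Statements on the series, on what has been measured and on what is new or still open speak of the compounds shown alone.

Of the compounds shown here, three built on a shared core have been measured in a functional assay on the whole organism with Mus musculus as the target; a higher number here means that more compound is needed for the effect, a lower number that less compound is needed. Compound 1 `O=C(/C=C1\CCc2cc(F)ccc21)NC1CC1` gives 81 mg/kg in this assay. Compound 2 `NC(=O)/C=C1\CCc2c1ccc(F)c2F` gives 45 mg/kg. Compound 3 `CCNC(=O)/C=C1\CCc2ccc(F)cc21` gives 70 mg/kg, the second highest of the three numbers; its nearest neighbour is compound 1 and its furthest is compound 2, and both differences lie within the scatter, so no order among the three can be drawn. Compound 4 `CCN(C)C(=O)/C=C1\CCc2ccc(F)cc21` has not been measured. It differs from compound 3 by methyl in place of hydrogen on an amide-type nitrogen. Going by the values given here, no step between two measured compounds is known, so this change has no precedent here; the expectation is a small step, if any, towards a higher number, with the expected step being a 1.3-fold higher number from compound 3 to compound 4 (0.11 log units; within the scatter). Compound 4 is estimated at 90 mg/kg, with a range from 45 mg/kg to 180 mg/kg.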

Compound 4, dose for half-maximal effect: 100 mg/kg
Beside the measured number, compound 4's estimate is 1.1-fold (0.05 log units) below it; measured number inside the range.
By their numbers in this assay, from the lowest: compounds 2, 3, 1 and 4 (each within the scatter of the next, the first and the last beyond it).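

Methyl in place of hydrogen on the amide-type nitrogen gives the first readable step on the shared core: in this assay the change brings a 1.4-fold higher number from compound 3 to compound 4 (0.15 log units; within the scatter), which lies within the scatter. Compound 4 has no amide hydrogen yet still gives a dose for half-maximal effect, so that hydrogen is not shown to be required for activity here. Going by these compounds, whether an ethyl, a longer chain or a hydroxyethyl group in place of this methyl would give a step beyond the scatter remains open. No measurement available here explains the size of this step.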